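Phenyl in place of pyridin-4-yl in compound 3

A few compounds are considered here, and "the series" means these few. Any claim that something is new, unique, unknown or untested is made for them only; others in the source may bear on it.

In a functional assay on KBVIN cells (Homo sapiens) for antiproliferative activity, read by sulforhodamine B assay, with a stated time of 3 days (on this read-out lower numbers stand for stronger inhibition of growth and higher numbers for weaker inhibition of growth), compound 1 `O=C(c1cccc(Nc2ncc(F)c(Nc3ccc(F)cc3)n2)c1)N1CCCCC1` gives 13800 nM and compound 2 `CN1CCC(C(=O)Nc2cccc(Nc3ncc(F)c(Nc4ccc(F)cc4)n3)c2)CC1` gives 11900 nM while compound 3 `O=C(Nc1cccc(Nc2ncc(F)c(Nc3ccc(F)cc3)n2)c1)c1ccncc1` stands lowest of the three at 4570 nM on this scale. Compound 4 `O=C(Nc1cccc(Nc2ncc(F)c(Nc3ccc(F)cc3)n2)c1)c1ccccc1` carries phenyl in place of pyridin-4-yl on a carbonyl carbon. For the measured compounds named here, no measured step makes this exact swap. The closest change, also on a carbonyl carbon, replaced 1-methylpiperidin-4-yl and was modest (a 2.6-fold lower number from compound 2 to compound 3 (0.42 log units; beyond the scatter)). Another was of similar size (a 3.0-fold lower number from compound 1 to compound 3 (0.48 log units; beyond the scatter)) and a third stayed within the scatter (a 1.2-fold lower number from compound 1 to compound 2 (0.06 log units; within the scatter)). Here one six-membered aromatic ring replaces another, so a smaller step is expected in this assay (a 1.1-fold higher number from compound 3 to compound 4 (0.04 log units; within the scatter)). Compound 4 is estimated at 5000 nM with an expected range from 2000 nM to 11000 nM in this read-out.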

Compound 4, concentration for 50% growth inhibition: > 10000 nM
Compound 4: no number, only a limit (the forecaster's own chance of this, stated with the estimate: 3%); middle value at least 2.0-fold (0.30 log units) from the limit.
By their numbers in this assay, from the lowest: compound 3; then compounds 2 and 1 (each within the scatter of the next).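

On this carbonyl carbon, one six-membered aromatic ring cannot simply stand in for the other: in this assay, replacing pyridin-4-yl with the all-carbon phenyl gives an at least 2.1-fold higher number from compound 3 to compound 4 (0.34 log units; beyond the scatter). The reading for compound 4 is a limit of the assay and not a number: the limit of > 10000 nM in this assay, at which 1 of the 4 values shown sits. The steps from compound 2 and compound 1 to compound 4 cannot be read against that limit.

On these data alone, how large the step from compound 3 truly is remains open. So does whether pyridin-3-yl, or a phenyl carrying an amine, would match pyridin-4-yl here.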